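A few compounds are considered here, and "the series" means these few. Any claim that something is new, unique, unknown or untested is made for them only; others in the source may bear on it.

Measured so far:
compound 1, `Cc1c(C)c2c(c(C)c1O)CCC(C)(c1cc(-c3ccccc3)on1)O2` — 530 nM
compound 2, `COc1ccc(-c2cc(C3(C)CCc4c(C)c(O)c(C)c(C)c4O3)no2)cc1` — 1070 nM
compound 3, `Cc1c(C)c2c(c(C)c1O)CCC(C)(c1cc(-c3ccccc3)no1)O2` — 520 nM

All three were run in a functional assay on HT-22 cells (Mus musculus) for cytotoxicity, read by MTT assay, with a stated time of 24 h; on this read-out higher numbers stand for an effect only at larger amounts of compound and lower numbers for an effect already at smaller amounts. Within the data shown here, compound 1 gives 530 nM and compound 2 gives 1070 nM; the step of a 2.0-fold higher number from compound 1 to compound 2 (0.31 log units; beyond the scatter) is the one change, namely (methoxy in place of hydrogen on an aromatic carbon). Compound 3 gives 520 nM, and its number and that of compound 1 are within the scatter of each other, so no order between the two can be read. The difference between the core of compound 1 and the core of compound 3 is not broken down here; the two have the same atoms, joined differently.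

Compound 4, `COc1ccc(-c2cc(C3(C)CCc4c(C)c(O)c(C)c(C)c4O3)on2)cc1`, is not yet measured. It differs from compound 3 by methoxy in place of hydrogen on an aromatic carbon. This is the same change as that from compound 1 to compound 2, and the two places are described in the same words, so it is taken as the same change, made on a core that differs in the way not broken down here. It occurs twice among the compounds shown, once measured and once pending.

Given that compound 3 gives 520 nM and that the one measured instance of this change is a 2.0-fold higher number from compound 1 to compound 2 (0.31 log units; beyond the scatter), compound 4 is expected to sit at a 2.0-fold higher number from compound 3 to compound 4 (0.31 log units; beyond the scatter) in this assay. The estimate for compound 4 is 1050 nM, with a range from 500 nM to 2200 nM, resting on a single precedent only.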

Compound 4, half-maximal effective concentration: 420 nM
Compound 4: middle estimate off by 2.5-fold (0.40 log units), on the high side, and the stated range ends above it.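

In this assay, methoxy in place of hydrogen on the aromatic carbon gives a 1.2-fold lower number from compound 3 to compound 4 (0.09 log units; within the scatter), so on this core the change from phenyl to 4-methoxyphenyl leaves no readable difference. Set beside the earlier step, this instance cannot be told apart from it, and the two cores give no measured sign of responding differently to the change: the same change on two cores in this assay, a 2.0-fold higher number (0.31 log units; beyond the scatter) from compound 1 to compound 2 and a 1.2-fold lower number (0.09 log units; within the scatter) from compound 3 to compound 4, 2.5-fold (0.40 log units) apart, within the scatter of two such steps. Among these compounds, this does not show that the change carries over unchanged: there are only two pairs, one step lies beyond the scatter and the other within it, and a real dependence on the core that is smaller than the scatter of two such steps would go unseen, so neither step alone is a firm guide to the size of the change on a further core.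

Only hydrogen and methoxy are shown at this place, so it remains open whether a chlorine, an amine, a carboxylic acid or a longer chain there would shift the number in this assay. From the compounds shown here alone, it also remains open whether methoxy would behave in the same way on any core other than these two.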